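The compounds below may be only part of what the source reports. "The series", "measured", "known", "first", "only" and "open" are said of these compounds alone.

Measured so far in a toxicity assay on cells (Erythrocyte, Mus musculus) for activation, read by spectrophotometry and hemolysis, with a stated time of 30 min; on this read-out higher numbers stand for an effect only at larger amounts of compound and lower numbers for an effect already at smaller amounts:
- Compound 1 `COc1cc(/C=N/Nc2nc3ccccc3s2)ccc1O`: > 200 ug/mL
- Compound 2 `Clc1ccc(/C=N/Nc2nc3ccccc3s2)cc1`: > 200 ug/mL
- Compound 3 `C(=N/Nc1nc2ccccc2s1)\c1ccc(-c2ccccn2)cc1`: > 200 ug/mL

Compound 3 stands at > 200 ug/mL, which is a limit and not a number. The same holds across the series, with the limit of > 200 ug/mL in this assay, at which 3 of the 3 values shown sit.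

Compound 4 `Oc1ccc(/C=N/Nc2nc3ccccc3s2)cc1` differs from compound 3 by hydroxy in place of pyridin-2-yl on an aromatic carbon.

Among the measured compounds shown here, the one measured step bearing on this change, a step that the two limits leave unreadable from compound 2 to compound 3, gives no size. Compound 1, which also carries hydroxy, likewise gives a limit, > 200 ug/mL. No step beyond the scatter is therefore expected in this assay, in either direction.

The expected change is a step that the limit leaves unreadable from compound 3 to compound 4. Compound 4 is estimated at 250 ug/mL, with an expected range from 120 ug/mL to 500 ug/mL.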

Compound 4, half-maximal effective concentration: > 200 ug/mL
Compound 4 ended at the assay's limit (the forecaster's own chance of this, stated with the estimate: 85%); the middle value lies beyond the limit too.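

In this assay compound 4 gives > 200 ug/mL which is a limit and not a number. Among the compounds shown here, no step among compound 1, compound 2, compound 3 and compound 4 can be read. The compounds shown leave open how their groups compare in this assay since all of them sit at one limit: the limit of > 200 ug/mL in this assay, at which 4 of the 4 values shown sit.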